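The source may hold more compounds than are shown below. What is called first, only, known or untested is meant among the compounds shown, and "the series" means these compounds.

Measured so far:
compound 1 `CN(C)C1(Cc2ccccc2)CCN(c2cc(C(F)(F)F)ccc2CNC(=O)Nc2ccc(CO)c(F)c2)CC1` — 81 nM
compound 2 `CN(C)C1(Cc2ccccc2)CCN(c2cc(C(F)(F)F)ccc2CNC(=O)Nc2ccc3c(c2)OCC3)CC1` — 31.3 nM

In an assay on CHO cells for antagonist activity at transient receptor potential cation channel subfamily V member 1 (Homo sapiens), read by scintillation counting, with a stated time of 5 min, in the presence of a further agent that is not named here (a higher number here means that more compound is needed for the effect, a lower number that less compound is needed), compound 1 gives 81 nM, the highest of the two numbers; compound 2 gives 31.3 nM, and the step of a 2.6-fold lower number from compound 1 to compound 2 (0.41 log units; beyond the scatter) is modest but beyond the scatter. Compound 3 `CN(C)C1(Cc2ccccc2)CCN(c2cc(C(F)(F)F)ccc2CNC(=O)Nc2cccc3ccncc23)CC1` is not yet measured; it differs from compound 1 by isoquinolin-8-yl in place of 3-fluoro-4-(hydroxymethyl)phenyl on an amide-type nitrogen. Within the data shown here, only the step from compound 1 to compound 2 bears on this, since it replaces the same group at the same place. A lowering of similar, modest size is therefore expected for compound 3, with wide uncertainty. Compound 3 is estimated at 45 nM, range 15 nM to 140 nM, that is an expected step of a 1.8-fold lower number from compound 1 to compound 3 (0.26 log units; within the scatter).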

Compound 3, half-maximal effective concentration: 18.7 nM
Compound 3: the middle estimate sits 2.4-fold (0.38 log units) above what was measured, and the stated range covers the measured number.
By their numbers in this assay, from the lowest: compounds 3 and 2 (each within the scatter of the next); then compound 1.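

In this assay, isoquinolin-8-yl in place of 3-fluoro-4-(hydroxymethyl)phenyl on the amide-type nitrogen gives a 4.3-fold lower number from compound 1 to compound 3 (0.64 log units; beyond the scatter), so a second, different group also lowers the number at this position. The two replacements are not told apart, with a 1.7-fold lower number from compound 2 to compound 3 (0.22 log units; within the scatter), although one group holds a nitrogen and the other an oxygen. No supporting data explain the change from compound 1. Going by these compounds, whether the isoquinoline nitrogen matters stays open against an all-carbon naphthalen-1-yl group. Also open, on these data alone, is whether the fluorine or the hydroxymethyl group accounts for the number of compound 1.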